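This account rests on a few compounds, and the source may have more. Where it says the series, first, only, none or still open, it means among the compounds named here.

Measured compounds:
compound 1 `COc1cc2ncnc(NNC(=S)NC(=O)c3ccccc3OC)c2cc1OC`, 8410 nM
compound 2 `O=C(NC(=S)NNc1ncnc2ccccc12)c1ccccc1`, 1490 nM
compound 3 `O=C(NC(=S)NNc1ncnc2ccccc12)c1ccc(C(F)(F)F)cc1`, 22500 nM

In a functional assay on CNE-2 cells (Homo sapiens) for cytotoxicity, read by MTT assay, with a stated time of 72 h (on this read-out lower numbers stand for stronger inhibition and higher numbers for weaker inhibition), compound 1 gives the second highest of the three numbers. Among the measured compounds shown here, its nearest neighbour is compound 3, which gives a higher number, and its furthest is compound 2, which gives a lower number; no single-point step connects compound 1 to either of them, so their values can only be set side by side.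

Compound 4 `COc1cc2ncnc(NNC(=S)NC(=O)c3ccccc3)c2cc1OC` has not yet been measured. It differs from compound 1 in one place: hydrogen in place of methoxy on an aromatic carbon. For the measured compounds named here, the only measured step that bears on a change to the same benzoyl ring is a 15-fold higher number from compound 2 to compound 3 (1.18 log units; beyond the scatter), where adding a group to that ring raised the number markedly. Removing a group from the same ring in compound 1 is therefore expected to move the number the other way, though the two groups are not the same and the core of compound 1 carries two methoxy groups that compound 2 lacks.

For compound 4 in this assay the estimate is 3000 nM, within 1000 nM to 9000 nM, which means an expected step of a 2.8-fold lower number from compound 1 to compound 4 (0.45 log units; beyond the scatter).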

Compound 4, half-maximal inhibitory concentration: 8180 nM
Compound 4: middle estimate off by 2.7-fold (0.44 log units), on the low side; low and high end bracket the measured number.
By their numbers in this assay, from the lowest: compound 2; then compounds 4 and 1 (each within the scatter of the next); then compound 3.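

In this assay, hydrogen in place of methoxy on an aromatic carbon, ortho to a large group, gives a 1.0-fold lower number from compound 1 to compound 4 (0.01 log units; within the scatter), so on the core of compound 1 the 2-methoxyphenyl and phenyl forms cannot be told apart by this read-out. Among the compounds shown here, the only earlier step on this ring, a 15-fold higher number from compound 2 to compound 3 (1.18 log units; beyond the scatter), came from a different group on a different core, and compound 4 now shows that a single change on the benzoyl ring need not shift the number beyond the scatter, at least for this group at this position. No measurement of any other kind is available here to account for this result.

The compounds shown leave open whether a different group at this same position, such as an amine, a carboxylic acid or a longer alkoxy chain, would also stay within the scatter of compound 4. They also leave open whether methoxy at this position would give a similar result on the core of compound 2, and whether trifluoromethyl would give as large a step on the core of compound 4.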